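Swapping the aryl group on the piperazine nitrogen: a third variation

The compounds below may be only part of what the source reports. "The series", "measured", "known", "first", "only" and "open" are said of these compounds alone.

Measured so far:
Compound 1, `Nc1scc(CN2CCN(c3ccc(Cl)cc3F)CC2)c1C(=O)c1ccc(Cl)cc1`: 1%
Compound 2, `Nc1scc(CN2CCN(c3ccncc3)CC2)c1C(=O)c1ccc(Cl)cc1`: 2%
Compound 3, `Nc1scc(CN2CCN(c3cccc4ccccc34)CC2)c1C(=O)c1ccc(Cl)cc1`: 0%

These three compounds share one core and differ only in the aromatic group attached to the amine nitrogen in the ring. In an assay on CHO cells for displacement of a labelled ligand from adenosine receptor A3 (Homo sapiens), read by scintillation counting, with a stated time of 120 min, tested at 10 uM (a higher number here means more inhibition at the concentration tested (going by the name of the read-out), a lower number less inhibition), compound 3 gives 0%, and none of the three values stands apart from the others beyond the scatter: the steps of a number 1 percentage points lower from compound 1 to compound 3 (within the scatter) and a number 2 percentage points lower from compound 2 to compound 3 (within the scatter) are both small, as is a number 1 percentage points higher from compound 1 to compound 2 (within the scatter).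

Compound 4, `Nc1scc(CN2CCN(c3cccc(F)c3)CC2)c1C(=O)c1ccc(Cl)cc1`, continues the same kind of variation, with 3-fluorophenyl in place of naphthalen-1-yl on an amine nitrogen in a ring. Within the data shown here, all the measured steps that exchange the group on this nitrogen stayed within the scatter, so there is no sign that the choice of aromatic group moves the read-out at all here. The step of a number 1 percentage points higher from compound 3 to compound 4 (within the scatter) is therefore expected to stay within the scatter as well. Compound 4 is estimated to give 1%, in a range from -6% to 8%.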

Compound 4, a percentage reported as inhibition, at one concentration (the size of the read-out at that concentration, not a potency): 4%
Beside the measured number, compound 4's estimate is 3 percentage points below it; measured number inside the range.
By their numbers in this assay, from the lowest: compounds 3, 1, 2 and 4 (each within the scatter of the next).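

Going from the two aromatic rings of naphthalen-1-yl to the single ring of 3-fluorophenyl on this nitrogen gives a number 4 percentage points higher from compound 3 to compound 4 (within the scatter) and so leaves this assay unmoved. The comparisons with the other two groups read the same way, with a number 2 percentage points higher from compound 2 to compound 4 (within the scatter) and a number 3 percentage points higher from compound 1 to compound 4 (within the scatter), so the four aromatic groups tried at this position cannot be told apart in this read-out. No further data are available here to explain this flat result.

From the compounds shown here alone, all four groups are aromatic rings attached directly to the nitrogen, so it remains open whether a benzyl group, a cyclohexyl ring or an acetyl group there would change the picture. Also open, going by these compounds, is whether a methoxy group in place of the chlorine on the aromatic ring of the shared core would change it.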